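A few compounds are considered here, and "the series" means these few. Any claim that something is new, unique, unknown or untested is made for them only; others in the source may bear on it.

Measured so far in a functional assay on MGC-803 cells (Homo sapiens) for antiproliferative activity, read by MTT assay; on this read-out lower numbers stand for stronger inhibition and higher numbers for weaker inhibition:
- compound 1, `COc1cc2ncnc(NCc3cccc(NC(=O)Nc4ccccc4C)c3)c2cc1OC` — a limit of the assay, > 50000 nM
- compound 2, `COc1ccccc1NC(=O)Nc1cccc(CNc2ncnc3cc(OC)c(OC)cc23)c1` — 7710 nM
- compound 3, `COc1ccc(NC(=O)Nc2cccc(CNc3ncnc4cc(OC)c(OC)cc34)c2)cc1` — 12300 nM

All three share one core and differ only in the phenyl ring on the urea. Compound 3 and compound 2 sit within the usual scatter of each other, as a 1.6-fold higher number from compound 2 to compound 3 (0.20 log units; within the scatter) shows. The value of compound 1 is a limit only, so its distance to the others is known just as a lower bound: an at least 6.4-fold lower number from compound 1 to compound 2 (0.81 log units; beyond the scatter) and an at least 4.0-fold lower number from compound 1 to compound 3 (0.60 log units; beyond the scatter).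

The next compound, compound 4, `COc1cc2ncnc(NCc3cccc(NC(=O)Nc4ccc(F)cc4)c3)c2cc1OC`, differs from compound 3 in one place: fluoro in place of methoxy on an aromatic carbon. Going by the values given here, none of the measured steps swaps these two groups at this position. The two steps that touch the same ring are an at least 4.0-fold lower number from compound 1 to compound 3 (0.60 log units; beyond the scatter), which changes the whole phenyl, and a 1.6-fold higher number from compound 2 to compound 3 (0.20 log units; within the scatter), which moves the methoxy and stays within the scatter. Nothing here points to a change beyond the scatter in this assay, so the estimate for compound 4 stays close to compound 3.

For compound 4 the expected value is 12000 nM, with a likely range from 4500 nM to 32000 nM. The expected step is a 1.0-fold lower number from compound 3 to compound 4 (0.01 log units; within the scatter).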

Compound 4, half-maximal inhibitory concentration: 42100 nM
Estimate against measurement, compound 4: 3.5-fold (0.55 log units) below; the whole stated range lies below it.
By their numbers in this assay, from the lowest: compounds 2 and 3 (each within the scatter of the next); then compound 4. At a limit, above all of these: compound 1.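

In this assay, what sits on the 4-methoxyphenyl ring turns out to matter: fluoro in place of methoxy gives a 3.4-fold higher number from compound 3 to compound 4 (0.53 log units; beyond the scatter), a modest step, so the two groups do not read the same at this position. The methoxy on the other ring position also stands apart from the 4-fluorophenyl compound, with a 5.5-fold higher number from compound 2 to compound 4 (0.74 log units; beyond the scatter), whereas moving the methoxy alone had stayed within the scatter, so in these compounds the kind of group tells more than its place on the ring. The step of an at least 1.1-fold lower number from compound 1 to compound 4 (0.07 log units; that floor lies within the scatter) cannot be read as a real difference, since compound 1 stands at a limit of the assay and not at a number: the limit of > 50000 nM in this assay, at which 1 of the 4 values shown sits.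

On these data alone, with a single replacement at this position, it stays open whether the higher number comes from losing the methoxy or from gaining the fluoro. A hydroxyl, an amine or a longer chain such as ethoxy at the same place would help to separate those two readings, and a 2-fluorophenyl partner would show whether fluoro behaves the same on another ring position.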